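The compounds below may be only part of what the source reports. "The series", "measured", "known", "first", "only" and "open" are said of these compounds alone.

Measured in a functional assay on L1210 cells (Mus musculus) for inhibition, read by MTT assay, with a stated time of 72 h; on this read-out lower numbers stand for stronger inhibition and higher numbers for weaker inhibition:
- compound 1 `COc1cc(NC(C)CCCNC(=O)Nc2ccc(Br)cc2)c2ncccc2c1`: 18000 nM
- compound 2 `COc1cc(NC(C)CCCNC(=O)NNC(=O)Nc2ccc(C(F)(F)F)cc2)c2ncccc2c1`: 18000 nM
- compound 3 `COc1cc(NC(C)CCCNC(=O)Nc2cc(C(F)(F)F)cc(C(F)(F)F)c2)c2ncccc2c1`: 3500 nM

Compound 2 stands level with compound 1, and together they hold the highest number of the three. Compound 3 lies lower, beyond the usual scatter. Compound 4 `COc1cc(NC(C)CCCNC(=O)NNC(=O)Nc2cccc(F)c2)c2ncccc2c1` differs from compound 2 in one place, with 3-fluorophenyl in place of 4-(trifluoromethyl)phenyl on an amide-type nitrogen. Within the data shown here, no two measured compounds differ in only one place, so the data offer no direct guide to this change. The best anchor is therefore compound 2 at 18000 nM, and no shift beyond the scatter is expected in either direction. The estimated change is a 1.1-fold higher number from compound 2 to compound 4 (0.05 log units; within the scatter). For compound 4 the expected value is 20000 nM, with an estimated range of 8000 nM to 50000 nM.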

Compound 4, half-maximal inhibitory concentration: 108000 nM
The estimate for compound 4 lay 5.4-fold (0.73 log units) below the measured number, outside the stated range (above it).
By their numbers in this assay, from the lowest: compound 3; then compounds 1 and 2 (each within the scatter of the next); then compound 4.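

In this assay, among these compounds, the group on this amide-type nitrogen proves to matter: 3-fluorophenyl in place of 4-(trifluoromethyl)phenyl gives a 6.0-fold higher number from compound 2 to compound 4 (0.78 log units; beyond the scatter), a shift that the earlier compounds gave no way of seeing. The larger change, ((3-fluorophenyl)carbamoyl)amino in place of 4-bromophenyl, gives a 6.0-fold higher number from compound 1 to compound 4 (0.78 log units; beyond the scatter), so compound 4 has the highest number, and thus the weakest inhibition, of the four. Nothing available here explains this rise.

A single swap cannot show which part of the change counts. As far as these compounds go, how a phenyl ring carrying an amine or a carboxylic acid would behave here remains open.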